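The source may hold more compounds than are shown below. What is called first, only, known or untested is meant among the compounds shown, and "the series" means these compounds.

Compound 1, `O=C1/C(=C/c2ccccc2)NS(=O)(=O)c2ccccc21`: in an assay for inhibition of alkaline phosphatase, tissue-nonspecific isozyme (Homo sapiens), read by spectrophotometry, with stated times of 10 min and 20 min (on this read-out higher numbers stand for weaker inhibition and lower numbers for stronger inhibition), compound 1 gives 660 nM.
Compound 2, `O=C1/C(=C/c2ccccc2Br)NS(=O)(=O)c2ccccc21`: compound 2 gives only a limit of this assay, > 200000 nM.
Compound 3, `O=C1/C(=C/c2cccc(Br)c2)NS(=O)(=O)c2ccccc21`: compound 3 also gives only a limit, > 200000 nM.

Compound 3 therefore stands at the weak end of what has been measured, sitting at the limit of > 200000 nM in this assay, at which 2 of the 3 values shown sit. The step of an at least 300-fold higher number from compound 1 to compound 3 (2.48 log units; beyond the scatter) shows how far a single bromo takes the inhibition past what this assay can read. Compound 4, `O=C1/C(=C/c2cccc(Cl)c2)NS(=O)(=O)c2ccccc21`, differs from compound 3 by chloro in place of bromo on an aromatic carbon. Within the data shown here, no measured step exchanges one halogen for another, so the steps that bear on it are an at least 300-fold higher number from compound 1 to compound 3 (2.48 log units; beyond the scatter) and an at least 300-fold higher number from compound 1 to compound 2 (2.48 log units; beyond the scatter), both large, with a halogen at either place removing readable inhibition. Compound 4 is expected to remain weak, with an estimated value near 100000 nM, between 10000 nM and 400000 nM. This expectation corresponds to an estimated step of an at least 2.0-fold lower number from compound 3 to compound 4 (0.30 log units; that floor lies within the scatter).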

Compound 4, half-maximal inhibitory concentration: > 200000 nM
Compound 4: only a limit was reported; the forecaster's own chance of this, stated with the estimate: 55%; middle value at least 2.0-fold (0.30 log units) away from the limit.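

Chloro in place of hydrogen at this position gives an at least 300-fold higher number from compound 1 to compound 4 (2.48 log units; beyond the scatter), so the large loss seen here with bromo is not particular to bromo. Compound 4 gives only a limit: the limit of > 200000 nM in this assay, at which 3 of the 4 values shown sit. The steps among compound 2, compound 3 and compound 4 cannot be read, as each joins two limits, so no order can be given among these halogen compounds.

Still open, as far as these compounds go, is whether any non-halogen group at this position, such as methoxy or an amine, keeps readable inhibition.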